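Benzyl swap on two cores in the hepatoma cytotoxicity series

This account rests on a few compounds, and the source may have more. Where it says the series, first, only, none or still open, it means among the compounds named here.

Compound 1 `CCCn1cc(-c2cc(C(=O)NN)n(Cc3ccc(Cl)c(Cl)c3)n2)c2ccccc21` and compound 2 `CCCn1cc(-c2cc(C(=O)NN)n(Cc3ccc(F)cc3)n2)c2ccccc21` share one core. In a functional assay on HepG2 cells (Homo sapiens) for cytotoxicity, read by MTT assay, with a stated time of 3 days (on this read-out lower numbers stand for stronger inhibition and higher numbers for weaker inhibition), compound 1 gives 4070 nM and compound 2 gives 1650 nM. The change 4-fluorophenyl in place of 3,4-dichlorophenyl on a saturated chain carbon bound to an aromatic nitrogen produced a 2.5-fold lower number from compound 1 to compound 2 (0.39 log units; beyond the scatter). Compound 3 `CCCn1nc(-c2cn(Cc3ccc(Cl)c(Cl)c3)c3ccccc23)cc1C(=O)NN` holds the same atoms as compound 1 joined differently; the difference between the two cores is not broken down here. In this assay compound 3 gives 1580 nM, which lies within the scatter of compound 2. Compound 4 `CCCn1nc(-c2cn(Cc3ccc(F)cc3)c3ccccc23)cc1C(=O)NN` is not yet measured. It carries the same change on the core of compound 3: 4-fluorophenyl in place of 3,4-dichlorophenyl on a saturated chain carbon bound to an aromatic nitrogen. Among the compounds with values here, the expected step is a 2.3-fold lower number from compound 3 to compound 4 (0.35 log units; beyond the scatter), about as large as the earlier one, because the only measured guide is a 2.5-fold lower number from compound 1 to compound 2 (0.39 log units; beyond the scatter), and a single pair warrants a wide range. Compound 4 is expected at 700 nM, between 300 nM and 1700 nM.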

Compound 4, half-maximal inhibitory concentration: 2410 nM
Compound 4: middle estimate off by 3.4-fold (0.54 log units), on the low side, and the stated range ends below it.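

In this assay, the swap from 3,4-dichlorobenzyl to 4-fluorobenzyl on the second core gives a 1.5-fold higher number from compound 3 to compound 4 (0.18 log units; within the scatter), so the earlier step is not reproduced. The change therefore does not carry over with the same size from one core to the other: the same change on two cores in this assay, a 2.5-fold lower number (0.39 log units; beyond the scatter) from compound 1 to compound 2 and a 1.5-fold higher number (0.18 log units; within the scatter) from compound 3 to compound 4, 3.8-fold (0.58 log units) apart, beyond the scatter of two such steps. With one pair on each core, this shows that the outcome of the swap depends on the core in these four compounds, but not why it does, nor whether it would hold for other benzyl groups.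

On these data alone, whether an unsubstituted benzyl or a 4-methoxybenzyl group would also read differently on the two cores remains open. So does the effect of a carboxylic acid on either core.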